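Notes on the aryl group attached to the carbonyl

A few compounds are considered here, and "the series" means these few. Any claim that something is new, unique, unknown or untested is made for them only; others in the source may bear on it.

Compound 1 `O=C(/C=C/c1ccc2c(c1)B(O)OC2)c1ccc(Cl)cc1` gives 9300 nM in a functional assay on HCT-116 cells (Homo sapiens) for cytotoxicity, read by MTT assay, with a stated time of 48 h (on this read-out higher numbers stand for weaker inhibition and lower numbers for stronger inhibition), the second highest of the three numbers measured. Compound 2 `O=C(/C=C/c1ccc2c(c1)B(O)OC2)c1ccc(OCc2ccccc2)cc1` gives 12100 nM, and compound 3 `O=C(/C=C/c1ccc2c(c1)B(O)OC2)c1ccc(Cl)c(Cl)c1` gives 3200 nM. The step of a 1.3-fold higher number from compound 1 to compound 2 (0.11 log units; within the scatter) lies within the scatter, so the two numbers are not told apart; the step of a 2.9-fold lower number from compound 1 to compound 3 (0.46 log units; beyond the scatter) is a modest lowering.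

Compound 4 `O=C(/C=C/c1ccc2c(c1)B(O)OC2)c1ccccc1O` has not yet been measured. It differs from compound 1 by 2-hydroxyphenyl in place of 4-chlorophenyl on a carbonyl carbon. For the measured compounds named here, no measured step changes the ring in this way: the step from compound 1 to compound 2 swaps one group for another on that ring and stays within the scatter, while the step from compound 1 to compound 3 adds a chloro and lowers the number modestly. Neither introduces a hydroxy group, and neither removes the chloro without replacement, so the two steps give only weak guidance. The expectation for compound 4 is therefore a step of a 1.1-fold higher number from compound 1 to compound 4 (0.03 log units; within the scatter) relative to compound 1, that is, no change beyond the scatter, with the direction uncertain. Compound 4 is expected to give about 10000 nM in this assay, within a range from 3500 nM to 30000 nM.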

Compound 4, half-maximal inhibitory concentration: 77900 nM
The estimate for compound 4 lay 7.8-fold (0.89 log units) below the measured number; the whole stated range lies below it.
By their numbers in this assay, from the lowest: compound 3; then compounds 1 and 2 (each within the scatter of the next); then compound 4.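

In this assay, 2-hydroxyphenyl in place of 4-chlorophenyl on the carbonyl carbon gives the first rise beyond the scatter in this small set (an 8.4-fold higher number from compound 1 to compound 4 (0.92 log units; beyond the scatter)), whereas benzyloxy in place of chloro stayed within it (a 1.3-fold higher number from compound 1 to compound 2 (0.11 log units; within the scatter)), so the aryl group at this position is not freely exchangeable. The change alters both the group on the ring and its place there, and among the steps shown it alone brings in a hydrogen-bond donor, so the single result cannot assign the rise to any one of these differences. No measurement that bears on the cause of this rise is available in the material at hand.

Going by these compounds, whether the rise follows the hydroxy group itself or its place on the ring remains open, as does how a methoxy group or an amine in its stead would read in this assay. Also open, on these data alone, is whether adding a chloro, which gave a modest lowering (a 2.9-fold lower number from compound 1 to compound 3 (0.46 log units; beyond the scatter)), would lower the number in the same way on the 2-hydroxyphenyl ring of compound 4.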